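A few compounds are considered here, and "the series" means these few. Any claim that something is new, unique, unknown or untested is made for them only; others in the source may bear on it.

- compound 1 `O=C1c2c[n+]([O-])c3ccccc3c2C(=O)c2c1c1ccccc1n2Cc1cn([C@H]2O[C@H](CO)[C@@H](O)[C@H]2O)nn1`: 710 nM
- compound 2 `CC1(C)OCC(Cn2cc(Cn3c4c(c5ccccc53)C(=O)c3c[n+]([O-])c5ccccc5c3C4=O)nn2)O1`: 70 nM
- compound 3 `O=C1c2c[n+]([O-])c3ccccc3c2C(=O)c2c1c1ccccc1n2Cc1cn(CC(O)CO)nn1`: 250 nM

All three values come from a functional assay on HCT-116 cells (Homo sapiens) for cytotoxicity, read by MTT assay, with a stated time of 72 h; on this read-out lower numbers stand for stronger inhibition and higher numbers for weaker inhibition. Compound 3, at 250 nM, sits in the middle of the three: a 2.8-fold lower number from compound 1 to compound 3 (0.45 log units; beyond the scatter), and a 3.6-fold higher number from compound 2 to compound 3 (0.55 log units; beyond the scatter).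

Compound 4 `O=C1c2c[n+]([O-])c3ccccc3c2C(=O)c2c1c1ccccc1n2Cc1cn([C@@H]2O[C@H](CO)[C@@H](O)[C@H](O)[C@H]2O)nn1` has not yet been measured. It keeps the shared core and changes one group: 3,4,5-trihydroxy-6-(hydroxymethyl)oxan-2-yl in place of 2,3-dihydroxypropyl on an aromatic nitrogen. For the measured compounds named here, no measured compound carries this exact group. The nearest match is in compound 1, which has 3,4-dihydroxy-5-(hydroxymethyl)oxolan-2-yl on the same aromatic nitrogen. That makes a 2.8-fold lower number from compound 1 to compound 3 (0.45 log units; beyond the scatter) the most useful guide: read in reverse, this modest step suggests that a ring bearing hydroxyl groups in place of 2,3-dihydroxypropyl would raise the number. The large step of a 10-fold lower number from compound 1 to compound 2 (1.01 log units; beyond the scatter) bears on it less, since compound 2 has no free hydroxyl groups in its side group. Three compounds are a thin basis for any trend.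

The expected change is a modest rise, a 2.6-fold higher number from compound 3 to compound 4 (0.41 log units; beyond the scatter). For compound 4 the estimated value is 650 nM, with an expected range of 250 nM to 1800 nM.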

Compound 4, half-maximal inhibitory concentration: 130 nM
The estimate for compound 4 lay 5.0-fold (0.70 log units) above the measured number, outside the stated range (below it).
By their numbers in this assay, from the lowest: compounds 2, 4 and 3 (each within the scatter of the next, the first and the last beyond it); then compound 1.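

In this assay, the 3,4,5-trihydroxy-6-(hydroxymethyl)oxan-2-yl group, a much larger ring carrying hydroxyl groups, is tolerated on this aromatic nitrogen about as well as 2,3-dihydroxypropyl (a 1.9-fold lower number from compound 3 to compound 4 (0.28 log units; within the scatter)) and (2,2-dimethyl-1,3-dioxolan-4-yl)methyl (a 1.9-fold higher number from compound 2 to compound 4 (0.27 log units; within the scatter)). Free hydroxyl groups on a ring at this position therefore do not by themselves go with a higher number, and compound 1 now stands apart from the other three, with two hydroxyl-bearing rings clearly separated (a 5.5-fold lower number from compound 1 to compound 4 (0.74 log units; beyond the scatter)). No measurement shown explains that separation.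

From the compounds shown here alone, whether ring size or the arrangement of the hydroxyl groups separates compound 1 from compound 4 stays open. So does whether an amine or a carboxylic acid on this ring, or a plain hexyl chain, would fit the same picture.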